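A few compounds are considered here, and "the series" means these few. Any claim that something is new, unique, unknown or untested is made for them only; others in the source may bear on it.

Of the compounds shown here, three built on one shared core have been tested in a functional assay (strain AB) with Danio rerio as the target, read by microscopy, with a stated time of 1 h; on this read-out lower numbers stand for an effect already at smaller amounts and higher numbers for an effect only at larger amounts of compound. Going by the values given here, compound 2 `CN1CCc2c(sc(NC(=O)Nc3ccc(Cl)cc3)c2C(N)=O)C1` is the only one to give a number: in this assay compound 2 gives 4700 nM. Compound 1 `CCN1CCc2c(sc(NC(=O)NCC3CCCO3)c2C(N)=O)C1` reaches only a limit in this assay, > 25000 nM. Compound 3 `CCN1CCc2c(sc(NC(=O)Nc3ccc(Cl)cc3)c2C#N)C1` likewise stops at a limit, > 25000 nM. Most of what is known is therefore (the limit of > 25000 nM in this assay, at which 2 of the 3 values shown sit), and no two measured compounds differ in a single place, so no step size has been observed. Compound 4 `CCCN1CCc2c(sc(NC(=O)Nc3ccc(Cl)cc3)c2C(N)=O)C1` differs from compound 2 by ethyl in place of hydrogen on a saturated chain carbon bound to an amine nitrogen in a ring. Among the compounds with values here, with no measured step of this kind, the expectation in this assay is a shift that is small, if at all beyond the scatter, leaning toward an effect only at larger amounts. Compound 4 is thus estimated at 7000 nM, within 2500 nM to 25000 nM. The expected step of a 1.5-fold higher number from compound 2 to compound 4 (0.17 log units; within the scatter) stays modest.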

Compound 4, half-maximal effective concentration: 3500 nM
Compound 4: the middle estimate sits 2.0-fold (0.30 log units) above what was measured; low and high end bracket the measured number.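

In this assay, putting ethyl in place of hydrogen on a saturated chain carbon bound to an amine nitrogen in a ring, which also reads as methyl to propyl, gives a 1.3-fold lower number from compound 2 to compound 4 (0.13 log units; within the scatter). Going by these compounds alone, this is the only measured step at this place, and because it lies within the scatter, compound 2 and compound 4 cannot be told apart here. A longer chain at this place is therefore compatible with an effect in this pair.

Going by these compounds, whether a carboxylic acid or a much longer chain would behave the same way stays open. Comparisons elsewhere on the shared core remain thin: the limit of > 25000 nM in this assay, at which 2 of the 4 values shown sit.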